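Lengthening the acyl chain from compound 3 to compound 4

The compounds below may be only part of what the source reports. "The series", "measured", "known", "first", "only" and "open" are said of these compounds alone.

In a functional assay on HeLa cells (Homo sapiens) for antiproliferative activity, read by MTT assay, with a stated time of 72 h (a higher number here means a weaker inhibitor, a lower number a stronger inhibitor), compound 3 (`CC/C=C/C(=O)Nc1cccc(Oc2nc(Nc3cccc(OC)c3)nc3c2CSCC3)c1`) gives 27200 nM. Compound 2 (`C=CC(=O)Nc1cccc(Oc2nc(Nc3cccc(OC)c3)nc3c2CSCC3)c1`) gives 28900 nM and compound 1 (`CCC/C=C/C(=O)Nc1cccc(Oc2nc(Nc3ccn(C)n3)nc3c2CSCC3)c1`) gives 17000 nM, so the three values lie within the scatter of one another.

Compound 4 (`CCC/C=C/C(=O)Nc1cccc(Oc2nc(Nc3cccc(OC)c3)nc3c2CSCC3)c1`) differs by methyl in place of hydrogen on a saturated chain carbon, two bonds along the chain from a double-bonded chain carbon, which turns but-1-en-1-yl into pent-1-en-1-yl. Within the data shown here, the one measured step that bears on this is also a chain change, a 1.1-fold lower number from compound 2 to compound 3 (0.03 log units; within the scatter). Among the measured compounds shown here, with only that small step as a guide, no change beyond the scatter is expected in this assay. The expected change is a 1.1-fold lower number from compound 3 to compound 4 (0.04 log units; within the scatter). For compound 4 the estimated value is 25000 nM, with an expected range of 13000 nM to 48000 nM.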

Compound 4, half-maximal inhibitory concentration: 33800 nM
Beside the measured number, compound 4's estimate is 1.4-fold (0.13 log units) below it; the range from low to high includes it.
By their numbers in this assay, from the lowest: compounds 1, 3, 2 and 4 (each within the scatter of the next).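

In this assay the added methyl on the saturated chain carbon gives the step (a 1.2-fold higher number from compound 3 to compound 4 (0.09 log units; within the scatter)), and pent-1-en-1-yl in place of vinyl gives the step (a 1.2-fold higher number from compound 2 to compound 4 (0.07 log units; within the scatter)), so across vinyl, but-1-en-1-yl and pent-1-en-1-yl the chain shows no effect beyond the scatter. With pent-1-en-1-yl held fixed, the group on the nitrogen can now be read as well (a 2.0-fold higher number from compound 1 to compound 4 (0.30 log units; within the scatter)), and this step also stays within the scatter. No measurement shown accounts for these values.

As far as these compounds go, whether a longer chain such as an octenyl group, or an amine at the chain end, would separate from these values stays open.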